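Side-chain exchange from compound 2 to compound 4

The source may report more compounds than this note shows. Statements on the series, on what has been measured and on what is new or still open speak of the compounds shown alone.

- compound 1 `O=C1c2c[n+]([O-])c3ccccc3c2C(=O)c2c1c1ccccc1n2Cc1cn([C@@H]2C[C@H](O)[C@@H](CO)O2)nn1`: 20 nM
- compound 2 `O=C1c2c[n+]([O-])c3ccccc3c2C(=O)c2c1c1ccccc1n2Cc1cn(C[C@H](O)CO)nn1`: 350 nM
- compound 3 `CC1(C)OCC(Cn2cc(Cn3c4c(c5ccccc53)C(=O)c3c[n+]([O-])c5ccccc5c3C4=O)nn2)O1`: 330 nM

Next up: compound 4 `O=C1c2c[n+]([O-])c3ccccc3c2C(=O)c2c1c1ccccc1n2CCN1CCCC1`, not yet measured.

In a functional assay on A-375 cells (Homo sapiens) for cytotoxicity, read by MTT assay, with a stated time of 72 h (on this read-out lower numbers stand for stronger inhibition and higher numbers for weaker inhibition), compound 2 stands at the weak end of the three, with its nearest neighbour given by a 1.1-fold lower number from compound 2 to compound 3 (0.03 log units; within the scatter). Its furthest neighbour is given by an 18-fold higher number from compound 1 to compound 2 (1.24 log units; beyond the scatter).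

The change to compound 4 is (pyrrolidin-1-yl)methyl in place of 1-(2,3-dihydroxypropyl)-1H-1,2,3-triazol-4-yl on a saturated chain carbon bound to an aromatic nitrogen. Cut one bond further out, (1-(2,3-dihydroxypropyl)-1H-1,2,3-triazol-4-yl)methyl becomes 2-(pyrrolidin-1-yl)ethyl.

The measured steps bear on this only indirectly, since all of them keep the triazole and change only the group on its nitrogen. These are a 17-fold higher number from compound 1 to compound 3 (1.22 log units; beyond the scatter), which is large, and the step from compound 2 to compound 3 above, which is within the scatter. For the measured compounds named here, no measured step removes the triazole, so the size stays uncertain.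

Compound 1 at 20 nM shows that the shared core can reach far lower numbers, so a moderate move downward in this assay is expected. The expected change is a 2.3-fold lower number from compound 2 to compound 4 (0.37 log units; beyond the scatter).

Compound 4 is estimated at 150 nM, with an expected range of 30 nM to 700 nM.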

Compound 4, half-maximal inhibitory concentration: 430 nM
The estimate for compound 4 lay 2.9-fold (0.46 log units) below the measured number; low and high end bracket the measured number.
By their numbers in this assay, from the lowest: compound 1; then compounds 3, 2 and 4 (each within the scatter of the next).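

Working from this assay, the exchange of (1-(2,3-dihydroxypropyl)-1H-1,2,3-triazol-4-yl)methyl for 2-(pyrrolidin-1-yl)ethyl on the aromatic nitrogen gives a step within the scatter (a 1.2-fold higher number from compound 2 to compound 4 (0.09 log units; within the scatter)). The earlier steps shown here all kept the triazole, whereas this one shows that the triazole and both hydroxyl groups can leave together without a change beyond the scatter. No measurement at hand accounts for this result.

Still open, as far as these compounds go, is whether the 4-hydroxy-5-(hydroxymethyl)oxolan-2-yl group, with compound 1 at (20 nM), would hold its low number without the triazole. Also open, from the compounds shown here alone, is how a morpholin-4-yl or dimethylamino group in place of the pyrrolidin-1-yl group, or a 3-(pyrrolidin-1-yl)propyl chain, would read.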